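The source may report more compounds than this note shows. Statements on the series, on what has been measured and on what is new or still open speak of the compounds shown alone.

Compound 1 `CC(C)(C)C1=CC(=O)C=C(NCCC(=O)O)C1=O` carries a (2-carboxyethyl)amino group on a small core. In an ADME assay on MRC5 cells (Homo sapiens) for cytotoxicity, read by MTT assay, with a stated time of 72 h (a lower number here means a stronger inhibitor, a higher number a weaker inhibitor), compound 1 reports only a limit, > 200000 nM. Compound 2 `CC(C)(C)C1=CC(=O)C=C(NCC(=O)O)C1=O` differs from it by carboxy in place of carboxymethyl on a saturated chain carbon bound to an amine nitrogen. In this assay compound 2 likewise reports only a limit, > 200000 nM. The step that the two limits leave unreadable from compound 1 to compound 2 stays unreadable because of the limit of > 200000 nM in this assay, at which 2 of the 3 values shown sit. Compound 3 `CC1=CCC[C@H]2[C@](C)(CC3=CC(=O)C=C(NCCC(=O)O)C3=O)[C@@H](C)CC[C@]12C` bears the same (2-carboxyethyl)amino group on a larger core; the difference between the two cores is not broken down here. In this assay compound 3 gives 80800 nM. Compound 4 `CC1=CCC[C@H]2[C@](C)(CC3=CC(=O)C=C(NCC(=O)O)C3=O)[C@@H](C)CC[C@]12C` differs from compound 3 by carboxy in place of carboxymethyl on a saturated chain carbon bound to an amine nitrogen, the same change as from compound 1 to compound 2, at the same place. Since that earlier step gave no readable size, compound 4 is expected to stay within the usual scatter, a step of a 1.2-fold higher number from compound 3 to compound 4 (0.09 log units; within the scatter). Compound 4 is accordingly estimated at 100000 nM, between 40000 nM and 200000 nM.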

Compound 4, half-maximal inhibitory concentration: 183000 nM
Compound 4: middle estimate off by 1.8-fold (0.26 log units), on the low side; low and high end bracket the measured number.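

On the larger core, carboxy in place of carboxymethyl gives a 2.3-fold higher number from compound 3 to compound 4 (0.36 log units; beyond the scatter) in this assay. The same change on the small core cannot be read, because compound 1 and compound 2 each report only a limit and not a number: the limit of > 200000 nM in this assay, at which 2 of the 4 values shown sit. The pair on the larger core is therefore the only readable case, and it does not show whether the step carries from one core to another.

The compounds shown leave open what a chain longer than 2-carboxyethyl would give in this assay. They also leave open what an amide in place of the carboxylic acid would give on either core.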